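Moving a methoxy to hydrogen on a chalcone-pyrazole scaffold

This account rests on a few compounds, and the source may have more. Where it says the series, first, only, none or still open, it means among the compounds named here.

Compound 1 `COc1cc(-c2cc(/C=C/C(=O)c3ccc(N)cc3)[nH]n2)cc(OC)c1OC` gives -55% in a functional assay on SF-268 cells (Homo sapiens) for cytotoxicity, read by sulforhodamine B assay, with a stated time of 48 h, tested at 10 uM; on this read-out higher numbers stand for a weaker effect at the one concentration tested and lower numbers for a stronger effect.
Compound 2 `COc1ccc(-c2cc(/C=C/C(=O)c3ccc(N)cc3)[nH]n2)cc1OC` gives -49% in this assay.
Compound 3 `COc1cc(C(=O)/C=C/c2cc(-c3cc(OC)c(OC)c(OC)c3)n[nH]2)cc(OC)c1OC` gives -45% in this assay.

All three measured compounds were tested in this assay, and their numbers sit close together. Compound 3 has the highest of the three, but its gap to compound 2 and to compound 1 is within the scatter, so no order among them can be read.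

Compound 2 comes from compound 1 by one change, (hydrogen in place of methoxy on an aromatic carbon), and that step is a number 6 percentage points higher from compound 1 to compound 2 (within the scatter), which is within the scatter.

Compound 4 `COc1ccc(-c2cc(/C=C/C(=O)c3cc(OC)c(OC)c(OC)c3)[nH]n2)cc1OC` is not yet measured. It comes from compound 3 by the same change, (hydrogen in place of methoxy on an aromatic carbon), on a core whose difference from the core of compound 1 is not broken down here.

Among the compounds with values here, since the only measured example of this change left the number essentially unmoved, the step for compound 4 is expected to be a number 5 percentage points higher from compound 3 to compound 4 (within the scatter), resting on the step of a number 6 percentage points higher from compound 1 to compound 2 (within the scatter) and on the value of compound 3, -45%.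

Compound 4 is therefore estimated to give -40% in this assay, likely between -55% and -25%.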

Compound 4, a percentage reported as activity, at one concentration (the size of the read-out at that concentration, not a potency): -56%
Beside the measured number, compound 4's estimate is 16 percentage points above it; the measured number lies below the stated range.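

On the core of compound 3, hydrogen in place of methoxy in this assay gave a number 11 percentage points lower from compound 3 to compound 4 (beyond the scatter), a modest step. Set beside the earlier step on the core of compound 1, this shows that the same change does not carry over from one core to the other as a single step, so the size seen on one core could not be relied on for the other: the same change on two cores in this assay, a number 6 percentage points higher (within the scatter) from compound 1 to compound 2 and a number 11 percentage points lower (beyond the scatter) from compound 3 to compound 4, 17 percentage points apart, beyond the scatter of two such steps

This rests on a single pair for each core, and it does not show which part of the two cores sets the steps apart, nor how the change would behave on any further core.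

The compounds shown leave open how other groups would compare with hydrogen in place of that methoxy, such as a hydroxyl or a fluorine. They also leave open whether a core carrying a carboxylic acid in place of the amine of compound 1 would follow either step.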